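Second Nitro Group on the Aromatic Ring: Cytotoxicity Outlook

This account rests on a few compounds, and the source may have more. Where it says the series, first, only, none or still open, it means among the compounds named here.

Compound 1 `CCOC(=O)N1CCC(=NNC(=O)c2ccc(F)cc2)CC1` is the fluoro member of the series. In a toxicity assay on BJ cells (Homo sapiens) for cytotoxicity, read by MTT assay, with a stated time of 24 h (a lower number here means a stronger inhibitor, a higher number a weaker inhibitor), compound 1 gives only a limit, > 400000 nM. Compound 2 `CCOC(=O)N1CCC(=NNC(=O)c2ccc([N+](=O)[O-])cc2)CC1` carries nitro in place of fluoro on an aromatic carbon. In this assay compound 2 likewise gives only a limit, > 400000 nM. The step that the two limits leave unreadable from compound 1 to compound 2 cannot be read, because of the limit of > 400000 nM in this assay, at which 2 of the 2 values shown sit. Compound 3 `CCOC(=O)N1CCC(=NNC(=O)c2ccc([N+](=O)[O-])cc2[N+](=O)[O-])CC1` brings a second nitro group: nitro in place of hydrogen on an aromatic carbon. Among the measured compounds shown here, the single measured step touches the same ring and gave no readable size; both measured compounds stand at the limit, so no size can be carried over to the new change. For compound 3 no step beyond the scatter in this assay is expected, and the value is expected to sit at the limit once more. The estimated step that the limit leaves unreadable from compound 2 to compound 3 is expected to be nil beyond the scatter. Compound 3 is estimated at 500000 nM, with an expected range from 150000 nM to 2000000 nM.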

Compound 3, half-maximal inhibitory concentration: > 400000 nM
Compound 3: a limit, no number; the forecaster's own chance of this, stated with the estimate: 75%; the middle value does not contradict the limit.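

No step can be read from compound 2 to compound 3 in this assay, because compound 3 also gives only a limit: the limit of > 400000 nM in this assay, at which 3 of the 3 values shown sit.

The compounds shown leave open whether the fluoro, the nitro or the second nitro group alters cytotoxicity in this assay at all.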